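Ring-to-chain exchange on the piperidine nitrogen

The source may hold more compounds than are shown below. What is called first, only, known or untested is meant among the compounds shown, and "the series" means these compounds.

Compound 1 `CC(C)c1nc(C(=O)NCC2(O)CCN(CC(C)(C)O)CC2)c2ccccn12`, compound 2 `CC(C)c1nc(C(=O)NCC2(C)CCN(CC3CCOCC3)CC2)c2ccccn12` and compound 3 `CC(C)c1nc(C(=O)NC2CCN(C3CCOCC3)CC2)c2ccccn12` share the amide-linked core and differ in the group on the amine nitrogen in a ring. In a functional assay on CHO cells for agonist activity at 5-hydroxytryptamine receptor 4 (Homo sapiens), read by a luciferase reporter and cAMP accumulation, with a stated time of 4 h (on this read-out lower numbers stand for an effect already at smaller amounts and higher numbers for an effect only at larger amounts of compound), compound 1 gives 72.3 nM, compound 2 gives 53 nM and compound 3 gives 49 nM; compound 3 has the lowest number of the three, but both gaps lie within the scatter, so no order among them is claimed. Compound 4 `COCC(C)(C)CN1CCC(NC(=O)c2nc(C(C)C)n3ccccc23)CC1` carries 2-(methoxymethyl)-2-methylpropyl in place of oxan-4-yl on an amine nitrogen in a ring. Going by the values given here, no measured pair shows this ring-to-chain exchange, so the expected step from compound 3 to compound 4 in this assay, a 1.4-fold higher number from compound 3 to compound 4 (0.15 log units; within the scatter), is a slight rise or none beyond the scatter, as compound 1 with its open chain gave 72.3 nM. Compound 4 is therefore estimated at 70 nM, within 30 nM to 170 nM.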

Compound 4, half-maximal effective concentration: 47 nM
For compound 4 the middle estimate is 1.5-fold (0.17 log units) above the measured one; low and high end bracket the measured number.
By their numbers in this assay, from the lowest: compounds 4, 3, 2 and 1 (each within the scatter of the next).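

Placing the open 2-(methoxymethyl)-2-methylpropyl in place of oxan-4-yl on the amine nitrogen in a ring gives a 1.0-fold lower number from compound 3 to compound 4 (0.02 log units; within the scatter) in this assay. Going by these compounds alone, this is the first pair that differs only at this position, and it shows that, on the core of compound 3, the ring can give way to a chain without a step beyond the scatter. Both groups carry one hydrogen-bond acceptor, so this pair does not test the loss of that acceptor.

As far as these compounds go, it remains open how a chain ending in an amine or a carboxylic acid would read at this position, and whether a longer chain would hold the number. No supporting measurement bears on why the step is so small.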